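Working notes: a methyl on the side chain and solubility

This account rests on a few compounds, and the source may have more. Where it says the series, first, only, none or still open, it means among the compounds named here.

Measured so far:
- compound 1, `CCc1nc2nc(C)cc(Nc3ccc(Cl)cc3)n2n1`: in a physicochemical assay for solubility, at pH 6.5 (on this read-out higher numbers stand for higher solubility and lower numbers for lower solubility), compound 1 gives 170000 nM.
- compound 2, `Cc1cc(Nc2ccc(S(F)(F)(F)(F)F)cc2)n2nc(C(C)(F)F)nc2n1`: in this assay compound 2 gives 30000 nM.
- compound 3, `CCC(F)(F)c1nc2nc(C)cc(Nc3ccc(S(F)(F)(F)(F)F)cc3)n2n1`: in this assay compound 3 gives 15000 nM.

Compound 1 holds the highest number of the three. The difference between the cores of compound 1 and compound 2 is not broken down here. From compound 2 to compound 3 the change is methyl in place of hydrogen on a saturated chain carbon, two bonds along the chain from an aromatic carbon and two fluorine atoms and it made the step of a 2.0-fold lower number from compound 2 to compound 3 (0.30 log units; within the scatter). Compound 4, `Cc1cc(Nc2ccc(Cl)cc2)n2nc(C(C)C)nc2n1`, awaits measurement; it differs from compound 1 by methyl in place of hydrogen on a saturated chain carbon bound to an aromatic carbon and a saturated chain carbon. The two places differ: in one the carbon sits two bonds along the chain from an aromatic carbon and two fluorine atoms, in the other it is bound to an aromatic carbon and a saturated chain carbon, so this is the same kind of change, not the same. In this assay a step of a 1.9-fold lower number from compound 1 to compound 4 (0.28 log units; within the scatter) is expected, resting on the earlier step because a 2.0-fold lower number from compound 2 to compound 3 (0.30 log units; within the scatter) stayed within the scatter. Compound 4 is estimated at 90000 nM, between 35000 nM and 220000 nM.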

Compound 4, solubility: 83000 nM
For compound 4 the middle estimate is 1.1-fold (0.04 log units) above the measured one, and the stated range covers the measured number.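

In this assay, methyl in place of hydrogen gives a 2.0-fold lower number from compound 1 to compound 4 (0.31 log units; beyond the scatter) and the same kind of change on the other core gives a 2.0-fold lower number from compound 2 to compound 3 (0.30 log units; within the scatter) so only the first of these two steps lies beyond the scatter. This shows that the change can be followed on both cores with steps of a printed size, but it rests on one pair per core and does not show that the step transfers, since the methyl sits at a different place in each pair and core and place cannot be told apart. No measurement at hand bears on why the steps take these sizes.

Open, as far as these compounds go, is whether an amine or a longer chain in place of that methyl would give a step of similar size on either core.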